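This account rests on a few compounds, and the source may have more. Where it says the series, first, only, none or still open, it means among the compounds named here.

Measured in a functional assay on T47D cells (Homo sapiens) for cytotoxicity, read by MTT assay, with a stated time of 72 h; on this read-out higher numbers stand for weaker inhibition of growth and lower numbers for stronger inhibition of growth:
compound 1, `COc1ccc(CS(=O)(=O)/C=C/c2ccc(OC)c(OC)c2OC)cc1[N+](=O)[O-]`: > 30000 nM, a limit of the assay
compound 2, `COc1ccc(CS(=O)(=O)/C=C/c2ccc(OC)c(OC)c2OC)cc1N`: 5900 nM
compound 3, `COc1ccc(CS(=O)(=O)CC(=O)Nc2ccccc2)cc1[N+](=O)[O-]`: > 30000 nM, a limit of the assay

Compound 1 and compound 2 differ by amino in place of nitro on an aromatic carbon. This gives an at least 5.0-fold lower number from compound 1 to compound 2 (0.70 log units; beyond the scatter); the step is counted from a limit, since compound 1 sits at the limit of > 30000 nM in this assay, at which 2 of the 3 values shown sit.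

Compound 4, `COc1ccc(CS(=O)(=O)CC(=O)Nc2ccccc2)cc1N`, has not yet been measured. It differs from compound 3 by amino in place of nitro on an aromatic carbon, the same change, at the same place in words. The difference between the two cores is not broken down here.

For compound 4 the step expected in this assay is an at least 2.5-fold lower number from compound 3 to compound 4 (0.39 log units; beyond the scatter), resting on the step of an at least 5.0-fold lower number from compound 1 to compound 2 (0.70 log units; beyond the scatter) and on compound 3 giving only a limit. The value estimated for compound 4 is 12000 nM, expected between 3000 nM and 40000 nM.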

Compound 4, concentration for 50% growth inhibition: > 30000 nM
Compound 4: a limit, no number; the forecaster's own chance of this, stated with the estimate: 35%; middle value at least 2.5-fold (0.39 log units) from the limit.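

Compound 3 and compound 4 both sit at a limit in this assay, so no step between them can be read: the limit of > 30000 nM in this assay, at which 3 of the 4 values shown sit.

From the compounds shown here alone, whether amino in place of nitro lowers the number at all on the core of compound 3 stays open.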